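Methyl for chloro on a weak Toll-like receptor 4 antagonist

The compounds below may be only part of what the source reports. "The series", "measured", "known", "first", "only" and "open" are said of these compounds alone.

Compound 1 `CCOc1ccc(OCCC(O)CN(C)Cc2c(C)nn(Cc3ccccc3Cl)c2C)cc1` was tested in an assay on cells for antagonist activity at Toll-like receptor 4 (Homo sapiens), with a stated time of 24 h (on this read-out higher numbers stand for weaker inhibition and lower numbers for stronger inhibition), and returned "not active" (no number reported), so no number stands for compound 1 there. Its relative compound 2 `CCCc1ccc(OCCC(O)CN(C)Cc2c(C)nn(Cc3ccccc3Cl)c2C)cc1` gave 24700 nM in this assay. Compound 3 `CCOc1ccc(OCCC(O)CN(C)Cc2c(C)nn(Cc3ccccc3C)c2C)cc1` differs from compound 1 as follows: methyl in place of chloro on an aromatic carbon. Among the measured compounds shown here, no measured pair shows this change, so only a small step in this assay, in either direction or none beyond the scatter, is expected. Compound 3 is therefore expected to stay weak in this assay, estimated at 40000 nM with a range of 15000 nM to 120000 nM, and a limit rather than a number is quite possible.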

Compound 3, half-maximal inhibitory concentration: 54600 nM
For compound 3 the middle estimate is 1.4-fold (0.14 log units) below the measured one; the measured number falls inside the stated range.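

Among the compounds shown here, compound 1 has no number in this assay, and no step from it to compound 3 can be read. From the compounds shown here alone, what methyl in place of chloro does to inhibition there stays open. No supporting measurement bears on this result.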